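A few compounds are considered here, and "the series" means these few. Any claim that something is new, unique, unknown or untested is made for them only; others in the source may bear on it.

Working notes on the series. Compound 1 `COc1cc(-c2nn(-c3cccc(NC(=O)c4ccc(Cl)c(C(F)(F)F)c4)c3)cc2-c2ccncc2)ccc1Cl` has been run in a functional assay on HCC 2998 cells (Homo sapiens) for inhibition, read by sulforhodamine B assay, with a stated time of 48 h; a lower number here means a stronger inhibitor of growth, a higher number a weaker inhibitor of growth; in this assay compound 1 gives > 32500 nM, which is a limit of the assay and not a number. Compound 1 therefore stands at the limit of > 32500 nM in this assay, at which 1 of the 2 values shown sits. Within the data shown here, compound 2 `O=C(Nc1cccc(-n2cc(-c3ccncc3)c(-c3ccc(Cl)c(O)c3)n2)c1)Nc1cc(C(F)(F)F)cc(C(F)(F)F)c1` is the one member with a numeric result: in this assay compound 2 gives 2410 nM. Among the measured compounds shown here, compound 2 differs from compound 1 in more than one place, so its value shows only that a member of the series reaches that level.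

Compound 3 `COc1cc(-c2nn(-c3cccc(NC(=O)Nc4cccc(C(F)(F)F)c4)c3)cc2-c2ccncc2)ccc1Cl` is not yet measured in this assay. Its change from compound 1 is (3-(trifluoromethyl)phenyl)amino in place of 4-chloro-3-(trifluoromethyl)phenyl on a carbonyl carbon. With compound 1 giving only a limit, the measured side of the step is open; the change is expected to move this assay toward stronger inhibition, perhaps not beyond the scatter. Compound 3 is expected to give 9000 nM, within a range from 2500 nM to 32500 nM. The step this estimate implies is an at least 3.6-fold lower number from compound 1 to compound 3 (0.55 log units; beyond the scatter).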

Compound 3, concentration for total growth inhibition: 3200 nM
Compound 3: middle estimate off by 2.8-fold (0.45 log units), on the high side; the measured number falls inside the stated range.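

Where 4-chloro-3-(trifluoromethyl)phenyl on a carbonyl carbon gives way to (3-(trifluoromethyl)phenyl)amino, the series now has a comparison in one place, and in this assay this change gives an at least 10-fold lower number from compound 1 to compound 3 (1.00 log units; beyond the scatter). The position therefore responds to the change, and a numeric result can be reached on the core of compound 1 without the other differences carried by compound 2. The size of the step is only a bound, and the value for compound 1 is a limit of the assay and not a number: the limit of > 32500 nM in this assay, at which 1 of the 3 values shown sits.

The chlorine leaves and the amino nitrogen enters in the same step, and the compounds shown do not separate the two. Also open, going by these compounds, is how a methylene in place of that amino nitrogen, or a carboxylic acid on the phenyl ring, would read in this assay.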